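The compounds below may be only part of what the source reports. "The series", "measured", "known", "first", "only" and "open" are said of these compounds alone.

Working notes on the series. Compound 1 (`O=C1Nc2ccc(S(=O)(=O)N3CCOCC3)cc2/C1=N/c1ccc(O)cc1`) gives 52700 nM in a functional assay on MCF7 cells (Homo sapiens) for cytotoxicity, read by sulforhodamine B assay, with a stated time of 24 h (on this read-out higher numbers stand for weaker inhibition and lower numbers for stronger inhibition), and compound 2 (`Cc1ccc(S(=O)(=O)N/N=C2\C(=O)Nc3ccc(S(=O)(=O)N4CCOCC4)cc32)cc1`) gives 38400 nM there, two values within the scatter of each other that share the weak end of the three numbers. Compound 3 (`O=C1Nc2ccc(S(=O)(=O)N3CCOCC3)cc2/C1=N/c1ccc(/N=C2\C(=O)Nc3ccc(S(=O)(=O)N4CCOCC4)cc32)cc1`) gives 10900 nM as a lower number than compound 1, beyond the scatter. Compound 4 (`O=C1Nc2ccc(S(=O)(=O)N3CCOCC3)cc2/C1=N/c1ccc(C(=O)O)cc1`) is not yet measured and departs from compound 1 by one change (carboxy in place of hydroxy on an aromatic carbon): carboxy in place of hydroxy on an aromatic carbon, para to a large group. Within the data shown here, no measured pair differs in one place, so nothing shows this change directly. In this assay no step beyond the scatter is expected, and no direction is favoured. The expected step of a 1.1-fold lower number from compound 1 to compound 4 (0.02 log units; within the scatter) is small. Compound 4 is estimated at 50000 nM with a range from 20000 nM to 100000 nM as the expected span.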

Compound 4, half-maximal inhibitory concentration: 26700 nM
Estimate against measurement, compound 4: 1.9-fold (0.27 log units) above, within the range that was stated.
By their numbers in this assay, from the lowest: compound 3; then compounds 4, 2 and 1 (each within the scatter of the next).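

Among these compounds, this is the only pair that differs in one place, and carboxy in place of hydroxy on an aromatic carbon, para to a large group, reads in this assay as a 2.0-fold lower number from compound 1 to compound 4 (0.30 log units; within the scatter). Going from 4-hydroxyphenyl to 4-carboxyphenyl therefore does not separate the two compounds on this read-out. No measurement at hand bears on what lies behind this result. Open, from the compounds shown here alone, is whether an amine or a methyl ester at this position would give a step beyond the scatter.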